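A few compounds are considered here, and "the series" means these few. Any claim that something is new, unique, unknown or untested is made for them only; others in the source may bear on it.

Measured so far:
compound 1, `O=C(NC1CCN(c2ncnc3[nH]ncc23)CC1)c1ccc(F)cc1`: 4540 nM
compound 2, `O=C(Nc1ccc(Br)cc1)NC1CCN(c2ncnc3[nH]ncc23)CC1`: 4030 nM

Both compounds share one core and differ only in the group attached to the carbonyl carbon. In an assay on isolated protein for inhibition of serine/threonine-protein kinase PAK 1 (Homo sapiens), read by ADP-Glo, with a stated time of 40 min (on this read-out higher numbers stand for weaker inhibition and lower numbers for stronger inhibition), compound 1 gives 4540 nM, and compound 2 gives 4030 nM. The step from compound 1 to compound 2 is a 1.1-fold lower number from compound 1 to compound 2 (0.05 log units; within the scatter), so the two values stand level within the usual scatter, and neither compound can be called stronger or weaker than the other on these numbers.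

Compound 3, `O=C(Nc1cccc(Cl)c1)NC1CCN(c2ncnc3[nH]ncc23)CC1`, is not yet measured. It differs from compound 2 in one place: 3-chlorophenyl in place of 4-bromophenyl on an amide-type nitrogen. For the measured compounds named here, only one measured step bears on a change of this kind: the exchange at the carbonyl carbon from compound 1 to compound 2 gave a 1.1-fold lower number from compound 1 to compound 2 (0.05 log units; within the scatter), a step within the scatter. Nothing measured here separates a 4-bromophenyl from a 3-chlorophenyl. The expected step is therefore a 1.0-fold lower number from compound 2 to compound 3 (0.00 log units; within the scatter), with no shift beyond the scatter. Compound 3 is estimated at 4000 nM, with a range from 1500 nM to 11000 nM.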

Compound 3, half-maximal inhibitory concentration: 1240 nM
For compound 3 the middle estimate is 3.2-fold (0.51 log units) above the measured one; measured number below the stated range.
By their numbers in this assay, from the lowest: compound 3; then compounds 2 and 1 (each within the scatter of the next).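

In this assay, the group on the amide-type nitrogen proves able to move the number: 3-chlorophenyl in place of 4-bromophenyl gives a 3.3-fold lower number from compound 2 to compound 3 (0.51 log units; beyond the scatter), whereas the earlier exchange stayed within the scatter. Against the 4-fluorophenyl on the carbonyl carbon, (3-chlorophenyl)amino gives a 3.7-fold lower number from compound 1 to compound 3 (0.56 log units; beyond the scatter), so compound 3 stands apart from both earlier compounds by a modest margin. Nothing available explains why this exchange lowers the number.

The change replaces the halogen and alters the number in the group's name at once, so 3-bromophenyl and 4-chlorophenyl would be needed to tell which of the two matters. Also open, from the compounds shown here alone, is how this nitrogen would respond to a group without a halogen, such as 3-methoxyphenyl, 3-aminophenyl or cyclohexyl.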